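Adding Fluorine Where Chlorine Already Cost Activity

The compounds below may be only part of what the source reports. "The series", "measured", "known", "first", "only" and "open" are said of these compounds alone.

Compound 1 `Fc1cc(-c2nnc3n2N=C(c2ccc(Cl)cc2)CS3)c(Cl)cc1Cl` gives 10600 nM in a functional assay on OVCAR-5 cells (Homo sapiens) for antiproliferative activity, read by sulforhodamine B assay, with a stated time of 48 h; on this read-out lower numbers stand for stronger inhibition of growth and higher numbers for weaker inhibition of growth. Compound 2 `Fc1cc(-c2nnc3n2N=C(c2ccc(Cl)cc2Cl)CS3)c(Cl)cc1Cl` reaches only the limit of the assay, > 100000 nM, so no exact number is known for it. The step of an at least 9.4-fold higher number from compound 1 to compound 2 (0.97 log units; beyond the scatter) shows that a chloro in place of hydrogen weakened growth inhibition sharply. Compound 3 `Fc1cc(C2=Nn3c(nnc3-c3cc(F)c(Cl)cc3Cl)SC2)c(Cl)cc1Cl` differs from compound 2 by fluoro in place of hydrogen on an aromatic carbon. Going by the values given here, no measured step follows a fluoro addition here, and compound 2 already sits at the limit of > 100000 nM in this assay, at which 1 of the 2 values shown sits. Compound 3 is therefore expected to stay beyond that limit, a step that the limit leaves unreadable from compound 2 to compound 3. For compound 3 the estimate is 150000 nM, within 30000 nM to 600000 nM.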

Compound 3, concentration for 50% growth inhibition: 56800 nM
Compound 3: the middle estimate sits 2.6-fold (0.42 log units) above what was measured; low and high end bracket the measured number.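

Placing fluoro on the 2,4-dichlorophenyl group gives an at least 1.7-fold lower number from compound 2 to compound 3 (0.24 log units; that floor lies within the scatter). That floor alone cannot prove a real gain, because compound 2 carries only a limit: the limit of > 100000 nM in this assay, at which 1 of the 3 values shown sits. The full change of 2,4-dichloro-5-fluorophenyl for 4-chlorophenyl still weakens growth inhibition, with a 5.4-fold higher number from compound 1 to compound 3 (0.73 log units; beyond the scatter), so fluoro does not restore what the added chloro lost. As far as these compounds go, how large the fluoro step truly is stays open. So does whether an amine or a carboxylic acid at this same position would behave as fluoro does.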